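Halogen pairing on the indole and the core

This account rests on a few compounds, and the source may have more. Where it says the series, first, only, none or still open, it means among the compounds named here.

Compound 3 `CO[C@@H]1[C@H](N(C)c2ncc(-c3c[nH]c4ccccc34)s2)C[C@H]2O[C@]1(C)n1c3ccccc3c3c4c(c5c6cc(Br)ccc6n2c5c31)C(=O)NC4` is measured in a functional assay on K562 cells (Homo sapiens) for antiproliferative activity, read by CellTiter-Glo, with a stated time of 72 h; a higher number here means a weaker inhibitor, a lower number a stronger inhibitor. In this assay compound 3 gives only a limit, > 10000 nM. Compound 2 `CO[C@@H]1[C@H](N(C)c2ncc(-c3c[nH]c4ccccc34)s2)C[C@H]2O[C@]1(C)n1c3ccccc3c3c4c(c5c6cc(Cl)ccc6n2c5c31)C(=O)NC4` likewise gives only a limit in this assay, > 10000 nM. Compound 1 `CO[C@@H]1[C@H](N(C)c2ncc(-c3c[nH]c4ccc(Cl)cc34)s2)C[C@H]2O[C@]1(C)n1c3ccccc3c3c4c(c5c6ccccc6n2c5c31)C(=O)NC4` also gives only a limit in this assay, > 10000 nM. Compound 3 therefore stands at the limit together with all other values shown, (the limit of > 10000 nM in this assay, at which 3 of the 3 values shown sit), so no order among the three can be read.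

Compound 4 `CO[C@@H]1[C@H](N(C)c2ncc(-c3c[nH]c4ccc(Cl)cc34)s2)C[C@H]2O[C@]1(C)n1c3ccccc3c3c4c(c5c6cc(Br)ccc6n2c5c31)C(=O)NC4` differs from compound 3 by chloro in place of hydrogen on an aromatic carbon. For the measured compounds named here, the one step that can be compared, a step that the two limits leave unreadable from compound 2 to compound 3, is a halogen swap on the core and not the same change; it is unreadable and gives no size. Compound 1 carries the chloro on the indole that compound 4 gains, yet also stays at the limit. Nothing in the series suggests a move away from the limit. The step from compound 3 to compound 4 is expected to be a step that the limit leaves unreadable from compound 3 to compound 4, that is none beyond the scatter. Compound 4 is estimated at 12000 nM, in the range 4000 nM to 50000 nM, most likely reported again as a limit.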

Compound 4, half-maximal inhibitory concentration: > 10000 nM
Compound 4: a limit, no number; the forecaster's own chance of this, stated with the estimate: 85%; the middle value lies beyond the limit too.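

For the compounds shown here, compound 4 gives only a limit in this assay, > 10000 nM, so no new step to it from compound 3 or compound 1 can be read. The compounds shown leave open whether any halogen on the indole or the core changes activity, and no order among them can be given: the limit of > 10000 nM in this assay, at which 4 of the 4 values shown sit.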